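Taking the Benzyloxy Group Off Compound 2

The compounds below may be only part of what the source reports. "The series", "measured", "known", "first", "only" and "open" are said of these compounds alone.

Two compounds share one core. In an ADME assay on HepG2 cells (Homo sapiens) for cytotoxicity, read by MTT assay, with a stated time of 48 h, tested at 1 uM (on this read-out higher numbers stand for a stronger effect at the one concentration tested and lower numbers for a weaker effect), compound 2 `O=c1cc(-c2ccc(OCc3ccccc3)cc2)oc2cc(OCCCCCCCCN3CCCC3)ccc12` gives 10.4%, a number that sits within the scatter of compound 1 `O=c1cc(-c2ccc(Cl)cc2)oc2cc(OCCCCCCCCN3CCCC3)ccc12`, which gives 6.39%. Among the compounds with values here, the one measured step, a number 4 percentage points higher from compound 1 to compound 2 (within the scatter), exchanged chloro for benzyloxy and stayed within the scatter. Compound 3 `O=c1cc(-c2ccccc2)oc2cc(OCCCCCCCCN3CCCC3)ccc12` differs from compound 2 by hydrogen in place of benzyloxy on an aromatic carbon. Within the data shown here, that small earlier step is the only guide, so compound 3 is expected to move little, a number 2.4 percentage points lower from compound 2 to compound 3 (within the scatter), and its estimated value is 8% with a range from 0% to 18%.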

Compound 3, a percentage reported as inhibition, at one concentration (the size of the read-out at that concentration, not a potency): 11.3%
Beside the measured number, compound 3's estimate is 3.3 percentage points below it, and the stated range covers the measured number.
By their numbers in this assay, from the lowest: compounds 1, 2 and 3 (each within the scatter of the next).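

In this assay, taking off the whole benzyloxy group, aromatic ring included, gives a number 0.9 percentage points higher from compound 2 to compound 3 (within the scatter), and hydrogen in place of chloro gives a number 4.9 percentage points higher from compound 1 to compound 3 (within the scatter). Hydrogen, chloro and benzyloxy on this aromatic carbon therefore cannot be told apart on this read-out, which the single earlier step could not show for hydrogen. No evidence on hand offers a reason for this. As far as these compounds go, whether an amine or a carboxylic acid at this position would stand apart from these three remains open. So does how these compounds would compare at other concentrations.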